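The source may report more compounds than this note shows. Statements on the series, on what has been measured and on what is new or still open speak of the compounds shown alone.

Compound 1 `Cc1cccnc1-c1ccc(C(=O)Nc2ccc(F)cc2)cc1` and compound 2 `CC(C)(C)c1ccc(NC(=O)c2ccc(-c3ncccc3NC3CCCC3)cc2)cc1` share a core in which an amide joins two six-membered aromatic rings, and both were tested in a functional assay for antagonist activity at transient receptor potential cation channel subfamily V member 1 (Rattus norvegicus); on this read-out higher numbers stand for weaker inhibition and lower numbers for stronger inhibition. Compound 1 gives only a limit of the assay, > 4000 nM, so no number is known for it. Compound 1 therefore sits at the limit of > 4000 nM in this assay, at which 1 of the 2 values shown sits, which is a limit and not a measured value. Among the measured compounds shown here, compound 2 gives 44 nM in this assay, and this is the only actual number among the two values shown.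

Compound 3 `CC(C)(C)c1ccc(NC(=O)c2ccc(-c3ncccc3-c3nn[nH]n3)cc2)cc1` has not yet been measured in this assay. It differs from compound 2 in one place: 2H-tetrazol-5-yl in place of cyclopentylamino on an aromatic carbon. For the measured compounds named here, no pair of measured compounds differing in one place is available, so the effect of such a swap cannot be read from measured steps. The expectation here is that inhibition weakens, with a step of a 34-fold higher number from compound 2 to compound 3 (1.53 log units; beyond the scatter) that is estimated to lie beyond the usual scatter. Compound 3 is therefore estimated at 1500 nM in this assay, with a range from 150 nM to 10000 nM.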

Compound 3, half-maximal inhibitory concentration: > 4000 nM
Compound 3: only a limit was reported (the forecaster's own chance of this, stated with the estimate: 35%); middle value at least 2.6-fold (0.42 log units) from the limit.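

In this assay, this position on the six-membered aromatic ring with 1 nitrogen proves sensitive to the group it carries: putting 2H-tetrazol-5-yl in place of cyclopentylamino gives an at least 90-fold higher number from compound 2 to compound 3 (1.95 log units; beyond the scatter), a large loss of inhibition. Both groups hold one five-membered ring and carry no net charge, so those two shared features alone are not enough to keep the inhibition seen with compound 2. On these data alone, compound 3 gives only a limit and not a number, so the true size of the step remains unknown: the limit of > 4000 nM in this assay, at which 2 of the 3 values shown sit.

The swap changes several things at once, replacing a non-aromatic ring of carbon only, joined through nitrogen, with an aromatic ring holding 4 hetero atoms, so these compounds cannot show which of those differences matters. As far as these compounds go, it also remains open how a simple amino group, a cyclopentyl group joined directly through carbon, or a carboxylic acid would behave at this position, and whether any of them would come closer to compound 2 or to compound 3.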